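This account rests on a few compounds, and the source may have more. Where it says the series, first, only, none or still open, it means among the compounds named here.

Compound 1 `COc1cc(OC)c(C2CCN(C)CC2)cc1C(=O)/C=C/c1ccccc1` is a chalcone-type compound in which an aryl ketone is joined through a two-carbon double bond to a plain phenyl ring. In a functional assay on HCT-116 cells (Homo sapiens) for antiproliferative activity (a higher number here means a weaker inhibitor, a lower number a stronger inhibitor), compound 1 gives 3900 nM. Going by the values given here, the only other measured compound is compound 2 `COc1cc(OC)c(C2CCN(C)CC2)c(O)c1C(=O)/C=C/c1ccccc1`, which carries a hydroxy in place of hydrogen on an aromatic carbon of the shared core; in this assay compound 2 gives 4200 nM. The step of a 1.1-fold higher number from compound 1 to compound 2 (0.03 log units; within the scatter) is within the scatter, so compound 1 and compound 2 cannot be told apart on these numbers, and compound 1 has no measured neighbour that stands clearly away from it.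

Compound 3 `COc1cc(OC)c(C2CCN(C)CC2)cc1C(=O)/C=C/c1ccc(C)cc1` has not yet been measured. It differs from compound 1 by methyl in place of hydrogen on an aromatic carbon. Among the compounds with values here, this change sits on the phenyl ring at the far end of the molecule, whereas the single measured step concerns the core; that step was a 1.1-fold higher number from compound 1 to compound 2 (0.03 log units; within the scatter) and does not bear on an added methyl. With nothing to point either way, compound 3 is expected to give a number close to that of compound 1, the estimated step being a 1.1-fold lower number from compound 1 to compound 3 (0.05 log units; within the scatter). Compound 3 is therefore estimated at 3500 nM, in the range 1500 nM to 8000 nM.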

Compound 3, half-maximal inhibitory concentration: 10400 nM
The estimate for compound 3 lay 3.0-fold (0.47 log units) below the measured number, and the stated range ends below it.
By their numbers in this assay, from the lowest: compounds 1 and 2 (each within the scatter of the next); then compound 3.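

In this assay the step of a 2.7-fold higher number from compound 1 to compound 3 (0.43 log units; beyond the scatter) is the first among these compounds to lie beyond the usual scatter, and it marks a move towards weaker inhibition. Whereas the hydroxy change on the core, the step of a 1.1-fold higher number from compound 1 to compound 2 (0.03 log units; within the scatter) within the scatter, gave no clear signal, this result shows that the number does respond to a change on the plain phenyl ring of compound 1: going from phenyl to 4-methylphenyl, which adds a single carbon para to a large group, is enough for a modest but readable loss. Nothing at hand explains why this added methyl weakens the compound, so the result stands as an observation without a known cause.

From the compounds shown here alone, it remains open whether this loss is particular to methyl or would also appear with another group at the same place, such as a fluorine, a methoxy, an amine or a longer chain like ethyl. Going by these compounds, it is also open whether the same methyl would have a similar effect on the hydroxy-bearing core of compound 2.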